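The source may hold more compounds than are shown below. What is called first, only, known or untested is meant among the compounds shown, and "the series" means these compounds.

Measured compounds:
- Compound 1 `CC1CCCN1c1nc(C(F)(F)F)ccc1CNC(=O)[C@@H](C)c1ccc(NS(C)(=O)=O)c(F)c1`: 0.3 nM
- Compound 2 `C[C@H](C(=O)NCc1ccc(C(F)(F)F)nc1N1CC[C@@H](N(C)C)C1)c1ccc(NS(C)(=O)=O)c(F)c1`: 101 nM

In a functional assay on CHO-K1 cells for antagonist activity at transient receptor potential cation channel subfamily V member 1 (Homo sapiens), read by FLIPR (on this read-out higher numbers stand for weaker inhibition and lower numbers for stronger inhibition), compound 1 gives 0.3 nM, and compound 2 gives 101 nM. For the measured compounds named here, compound 2 therefore stands at the highest number of the two, with compound 1 as its only neighbour; the move a 340-fold higher number from compound 1 to compound 2 (2.53 log units; beyond the scatter) came with 3-(dimethylamino)pyrrolidin-1-yl in place of 2-methylpyrrolidin-1-yl on an aromatic carbon.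

Compound 3 `C[C@H](C(=O)NCc1ccc(C(F)(F)F)nc1N1CC[C@H](N(C)C)C1)c1ccc(NS(C)(=O)=O)c(F)c1` has not yet been measured in this assay. Its difference from compound 2 is the two compounds have the same atoms and bonds and differ only in configuration as drawn: 1 of 2 stereo elements differ; a stereocentre at a saturated ring carbon is drawn R in compound 2 and S in compound 3. Going by the values given here, no measured step bears directly on this change: the one step known, a 340-fold higher number from compound 1 to compound 2 (2.53 log units; beyond the scatter), exchanges the whole ring substituent and says nothing about turning one ring stereocentre from R to S. On that basis no particular direction can be argued, and the step of a 1.0-fold lower number from compound 2 to compound 3 (0.00 log units; within the scatter) is expected to be small relative to what is known, though the range must be kept wide. Compound 3 is thus estimated at 100 nM, between 15 nM and 600 nM, in this assay.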

Compound 3, inhibition constant: 103 nM
For compound 3 the middle estimate is 1.0-fold (0.01 log units) below the measured one; measured number inside the range.
By their numbers in this assay, from the lowest: compound 1; then compounds 2 and 3 (each within the scatter of the next).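

In this assay, the configuration of the ring carbon that carries the dimethylamino group makes no measurable difference, with a 1.0-fold higher number from compound 2 to compound 3 (0.01 log units; within the scatter). The large loss seen earlier with the R form is therefore not tied to one configuration, since the S form shows the same gap, with a 340-fold higher number from compound 1 to compound 3 (2.54 log units; beyond the scatter). The pair isolates this single stereocentre, because nothing else separates the two compounds: the fact that compounds 2 and 3 differ only in the configuration as drawn.

The compounds shown do not separate the parts of the exchange, since 3-(dimethylamino)pyrrolidin-1-yl differs from 2-methylpyrrolidin-1-yl both in the group it carries and in where that group sits, so either could account for the loss. On these data alone, it remains open whether a pyrrolidin-1-yl ring bearing a hydroxyl or an unsubstituted amine in place of dimethylamino would recover any of the activity of compound 1, and whether configuration would matter there, as the indifference seen here is established only for the dimethylamino pair.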